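Ring size at the thiocarbonyl amine: piperidinyl to pyrrolidinyl

A few compounds are considered here, and "the series" means these few. Any claim that something is new, unique, unknown or untested is made for them only; others in the source may bear on it.

Measured so far:
- compound 1, `Cc1cccc(/C(N)=N/NC(=S)N2CCSCC2)n1`: 73.1%
- compound 2, `Cc1cccc(/C(N)=N/NC(=S)N2CCOCC2)n1`: 74.3%
- compound 3, `Cc1cccc(/C(N)=N/NC(=S)N2CCCCC2)n1`: 80.9%

All three share one core and differ only in the saturated ring on the thiocarbonyl carbon. In a functional assay on A-375 cells (Homo sapiens) for cytotoxicity, read by MTT assay, with a stated time of 72 h, tested at 30 uM (on this read-out higher numbers stand for more inhibition of growth at the one concentration tested and lower numbers for less inhibition of growth), compound 3 gives the highest of the three numbers, but its steps to the other two, a number 6.6 percentage points higher from compound 2 to compound 3 (within the scatter) and a number 7.8 percentage points higher from compound 1 to compound 3 (within the scatter), both lie within the scatter, so the three compounds cannot be ordered on this read-out. The step of a number 1.2 percentage points higher from compound 1 to compound 2 (within the scatter) is likewise within the scatter.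

Compound 4, `Cc1cccc(/C(N)=N/NC(=S)N2CCCC2)n1`, has not been measured. It differs from compound 3 as follows: pyrrolidin-1-yl in place of piperidin-1-yl on a thiocarbonyl carbon. The measured steps that bear on this change are those that swap the ring on the thiocarbonyl carbon, namely from compound 1 and from compound 2 to compound 3; none of them moved the number beyond the scatter. Since every exchange of the saturated ring at this place has so far left the read-out essentially unchanged, no step beyond the scatter is expected for a number 4.9 percentage points lower from compound 3 to compound 4 (within the scatter) either. On that basis compound 4 is expected to give 76% in this assay, with a range of 62% to 88%.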

Compound 4, percent growth inhibition at one concentration: 60.8%
Compound 4: the middle estimate sits 15.2 percentage points above what was measured, and the stated range ends above it.
By their numbers in this assay, from the lowest: compound 4; then compounds 1, 2 and 3 (each within the scatter of the next).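

The saturated ring on the thiocarbonyl carbon is no longer indifferent in this assay: the change to pyrrolidin-1-yl gives a number 20.1 percentage points lower from compound 3 to compound 4 (beyond the scatter) and the same ring also gives a number 13.5 percentage points lower from compound 2 to compound 4 (beyond the scatter) as well as a number 12.3 percentage points lower from compound 1 to compound 4 (beyond the scatter). Piperidin-1-yl, morpholin-4-yl and thiomorpholin-4-yl stay within the scatter of one another, so among these four compounds, exchanging the hetero atom within a six-membered ring yields no readable step, while compound 4, the only one with a five-membered non-aromatic ring, stands apart from all three. Nothing available explains why this single change separates compound 4 from the others.

Still open, on these data alone, is whether the separation follows ring size in general: azepan-1-yl on the same thiocarbonyl carbon, or an open-chain diethylamino group, would show whether the number stays with the piperidin-1-yl group or falls towards that of the pyrrolidin-1-yl group. As far as these compounds go, as the read-out rests on one concentration, it also remains open whether the step would persist as a difference across a full concentration range.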